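Swapping an acyl hydrazide for a hydrazone on a quinoxalinone

A few compounds are considered here, and "the series" means these few. Any claim that something is new, unique, unknown or untested is made for them only; others in the source may bear on it.

Measured compounds:
- compound 1, `O=C(NNc1nc2ccccc2nc1Cc1ccccc1)c1ccc(Cl)cc1`: 730000 nM
- compound 2, `COc1ccc(C(=O)NNc2nc3ccccc3nc2Cc2ccccc2)cc1`: 920000 nM
- compound 3, `Cc1ccc(C(=O)NNC(=O)Cn2c(=O)c(Cc3ccccc3)nc3ccccc32)cc1`: 680000 nM

All three compounds were tested in an assay for inhibition of Amine oxidase [flavin-containing] B (Bos taurus), read by fluorescence, with a stated time of 60 min; a lower number here means a stronger inhibitor, a higher number a weaker inhibitor. Compound 1 gives 730000 nM, compound 2 gives 920000 nM, and compound 3 gives 680000 nM. Among the compounds with values here, the only step between closely related pairs, a 1.3-fold higher number from compound 1 to compound 2 (0.10 log units; within the scatter), is within the scatter. Compound 3 has the lowest of the three numbers, but its gaps to compound 1 and to compound 2 are both within the scatter, so the three are best read as alike in this assay.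

Compound 4, `O=C(Cn1c(=O)c(Cc2ccccc2)nc2ccccc21)N/N=C/c1ccccc1`, differs from compound 3 by a group of 8 heavy atoms (7 carbon, 1 nitrogen; one six-membered aromatic ring of carbon only) in place of a group of 10 heavy atoms (8 carbon, 1 nitrogen, 1 oxygen; one six-membered aromatic ring of carbon only), on an amide-type nitrogen. Within the data shown here, no measured step touches this part of the molecule; the one step seen, from compound 1 to compound 2, changes a substituent elsewhere and is within the scatter. With nothing shown to move the number, the expectation for compound 4 is a value close to that of compound 3, the expected step being a 1.0-fold higher number from compound 3 to compound 4 (0.01 log units; within the scatter). Compound 4 is therefore estimated at 700000 nM, with a likely range from 300000 nM to 1600000 nM.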

Compound 4, half-maximal inhibitory concentration: 880000 nM
Estimate against measurement, compound 4: 1.3-fold (0.10 log units) below; measured number inside the range.
By their numbers in this assay, from the lowest: compounds 3, 1, 4 and 2 (each within the scatter of the next).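

Within the data shown here, this is the first change at the amide-type nitrogen, and it alters far more than the earlier chloro to methoxy swap: the ((4-methylphenyl)carbonyl)amino group leaves, and a smaller group with no hydrogen-bond donor enters. Even so, this assay gives a 1.3-fold higher number from compound 3 to compound 4 (0.11 log units; within the scatter) and so does not tell the two compounds apart. Thus neither the loss of that donor nor the drop in heavy atoms has been shown to move the number in this pair, and no separate measurement offers an explanation for the result.

Because the two groups differ in several ways at once, this single pair cannot show how each difference would act alone. Going by these compounds, it also remains open whether a different group on this nitrogen, such as an amine, a carboxylic acid or a longer carbon chain, would give a step beyond the scatter.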